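This account rests on a few compounds, and the source may have more. Where it says the series, first, only, none or still open, it means among the compounds named here.

Measured in a functional assay on HT-29 cells (Homo sapiens) for cytotoxicity, read by MTT assay, with a stated time of 72 h; a higher number here means a weaker inhibitor, a lower number a stronger inhibitor:
compound 1 `O=C(CN1CCN(c2nnc(Cc3ccncc3)c3ccccc23)CC1)Nc1cccc(F)c1` gives 6130 nM
compound 2 `O=C(CN1CCN(c2nnc(Cc3ccccc3)c3ccccc23)CC1)Nc1ccc(F)c(F)c1` gives 9510 nM
compound 3 `O=C(CN1CCN(c2nnc(Cc3ccccc3)c3ccccc23)CC1)Nc1ccc(Br)cc1` gives 60200 nM

Compound 2 lies within the scatter of compound 1, while compound 3 stands apart, with a 6.3-fold higher number from compound 2 to compound 3 (0.80 log units; beyond the scatter) at the amide-type nitrogen. Compound 4 `O=C(CN1CCN(c2nnc(Cc3ccncc3)c3ccccc23)CC1)Nc1ccc(F)c(F)c1` instead has pyridin-4-yl in place of phenyl on a saturated chain carbon bound to an aromatic carbon. Going by the values given here, the one measured step lies elsewhere in the molecule, and no measured pair isolates this change. Compound 1 carries pyridin-4-yl but also differs on the amide side, so it offers only loose support. No step beyond the scatter is therefore expected in this assay, and the estimate is a 1.3-fold lower number from compound 2 to compound 4 (0.10 log units; within the scatter). Compound 4 is expected at 7500 nM, with an estimated range from 2500 nM to 22000 nM.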

Compound 4, half-maximal inhibitory concentration: 2320 nM
Estimate against measurement, compound 4: 3.2-fold (0.51 log units) above; the whole stated range lies above it.
By their numbers in this assay, from the lowest: compound 4; then compounds 1 and 2 (each within the scatter of the next); then compound 3.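

In this assay, going by these compounds alone, pyridin-4-yl in place of phenyl on a saturated chain carbon bound to an aromatic carbon gives a 4.1-fold lower number from compound 2 to compound 4 (0.61 log units; beyond the scatter), the first measured step at this position, and it lies beyond the scatter. With pyridin-4-yl held constant, fluoro in place of hydrogen on an aromatic carbon gives a 2.6-fold lower number from compound 1 to compound 4 (0.42 log units; beyond the scatter), so the amide side also still registers in this setting. Nothing measured here explains either step.

The compounds shown leave open whether pyridin-3-yl or pyridin-2-yl would match pyridin-4-yl on this carbon. They also leave open whether the same exchange would give a similar step alongside the 4-bromophenyl group of compound 3.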